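Removing the Amide from a Methoxy-Rich Aromatic Core

A few compounds are considered here, and "the series" means these few. Any claim that something is new, unique, unknown or untested is made for them only; others in the source may bear on it.

Four compounds share a core carrying several methoxy groups and an aromatic amine. Compound 1 `COc1ccc(C(=O)c2cc(OC)c(OC)c(OC)c2)cc1N` is the free amine, and in a functional assay on B16 cells (Mus musculus) for cytotoxicity, read by MTT assay, with a stated time of 72 h (on this read-out lower numbers stand for stronger inhibition and higher numbers for weaker inhibition), compound 1 gives 30 nM. Compound 2 `COc1ccc(C(=O)c2cc(OC)c(OC)c(OC)c2)cc1NC(=O)/C=C/c1ccc(F)cc1` carries an amide on that nitrogen; in this assay compound 2 gives 400 nM. Compound 3 `COc1cc(C(=O)c2cc(OC)c(OC)c(OC)c2)cc(NC(=O)/C=C/c2ccc(F)cc2)c1OC` differs from compound 2 in one place, (methoxy in place of hydrogen on an aromatic carbon), and in this assay compound 3 gives 900 nM, the highest of the three measured numbers. That step is modest: a 2.3-fold higher number from compound 2 to compound 3 (0.35 log units; beyond the scatter). Compound 4 `COc1cc(C(=O)c2cc(OC)c(OC)c(OC)c2)cc(N)c1OC` has not yet been measured.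

The difference between compound 2 and compound 1 is hydrogen in place of (2-(4-fluorophenyl)ethenyl)carbonyl on a nitrogen on an aromatic ring, and the step it made was large: a 13-fold lower number from compound 2 to compound 1 (1.12 log units; beyond the scatter). Compound 4 differs from compound 3 by the same kind of change, (hydrogen in place of (2-(4-fluorophenyl)ethenyl)carbonyl on a nitrogen on an aromatic ring). The surroundings of the nitrogen are the same in both pairs, and the two cores differ only by methoxy in place of hydrogen on an aromatic carbon, so the expectation rests on one measured step of this change and on the modest gap between the two cores.

Compound 4 is expected to land near 70 nM, with a likely range from 20 nM to 250 nM. That estimate implies a step of a 13-fold lower number from compound 3 to compound 4 (1.11 log units; beyond the scatter), similar in size to the measured step between compound 2 and compound 1, while keeping compound 4 somewhat above compound 1 because compound 3 gives 900 nM against the lower number of compound 2.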

Compound 4, half-maximal inhibitory concentration: 12500 nM
Compound 4: middle estimate off by 180-fold (2.25 log units), on the low side, outside the stated range (above it).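

On the core of compound 3, taking the (2-(4-fluorophenyl)ethenyl)carbonyl group off the nitrogen gives a 14-fold higher number from compound 3 to compound 4 (1.14 log units; beyond the scatter) in this assay, so the change that lowered the number on one core raised it by a similar amount on the other: the same change on two cores in this assay, a 13-fold lower number (1.12 log units; beyond the scatter) from compound 2 to compound 1 and a 14-fold higher number (1.14 log units; beyond the scatter) from compound 3 to compound 4, 190-fold (2.27 log units) apart, beyond the scatter of two such steps

The added methoxy group shows the same dependence from the other side, giving a 420-fold higher number from compound 1 to compound 4 (2.62 log units; beyond the scatter) when the nitrogen carries a free amino group, a far larger step than with the amide in place: the same change on two cores in this assay, a 2.3-fold higher number (0.35 log units; beyond the scatter) from compound 2 to compound 3 and a 420-fold higher number (2.62 log units; beyond the scatter) from compound 1 to compound 4, 190-fold (2.27 log units) apart, beyond the scatter of two such steps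

In these four compounds, then, the effect of either change depends on the other, and a step measured on one core could not be carried to the second core; this rests on a single set of four compounds in one assay, and it does not show why the steps differ or how any further core would behave.

Going by these compounds, it remains open whether the reversal is specific to methoxy on that aromatic carbon, since a hydroxyl group or a chlorine atom there could behave differently. On these data alone, it is equally open whether it needs the full (2-(4-fluorophenyl)ethenyl)carbonyl group, which a small acetyl group on the nitrogen would help to separate.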